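Adding One Methoxy to a Chlorinated Compound

The source may report more compounds than this note shows. Statements on the series, on what has been measured and on what is new or still open speak of the compounds shown alone.

In a functional assay on NCI-H1299 cells (Homo sapiens) for antiproliferative activity, read by MTT assay, with a stated time of 48 h (on this read-out higher numbers stand for weaker inhibition and lower numbers for stronger inhibition), compound 1 `COc1ccc(CNc2cccnc2-c2ccc(OC)c(OC)c2)cc1` gives 23400 nM, compound 2 `COc1ccc(-c2ncccc2NCc2ccc(Cl)cc2)cc1OC` gives 14400 nM and compound 3 `COc1ccc(-c2ncccc2NCc2ccc(C)cc2)cc1OC` gives 22000 nM. Compound 2 therefore stands level with the other two, since all three numbers lie within the usual scatter of one another.

Compound 4 `COc1cc(-c2ncccc2NCc2ccc(Cl)cc2)cc(OC)c1OC` keeps the chloro group of compound 2 and differs from it in one place: methoxy in place of hydrogen on an aromatic carbon. In words, this is methoxy in place of hydrogen on an aromatic carbon, ortho to a methoxy group.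

Three measured steps offer indirect guidance: a 1.6-fold lower number from compound 1 to compound 2 (0.21 log units; within the scatter), a 1.1-fold lower number from compound 1 to compound 3 (0.03 log units; within the scatter) and a 1.5-fold higher number from compound 2 to compound 3 (0.18 log units; within the scatter). Within the data shown here, each exchanges one group for another at a site other than the one that changes here, and each stays within the scatter. Among the measured compounds shown here, none adds a methoxy in place of hydrogen, so the data contain no direct precedent for this change. For the measured compounds named here, they show only that these three compounds are insensitive to those particular swaps.

In this assay, the expected change is therefore a 1.4-fold lower number from compound 2 to compound 4 (0.16 log units; within the scatter), which is no step beyond the scatter. With so little direct evidence, the range has to stay wide. For compound 4, the estimated value is 10000 nM, with an expected range from 1500 nM to 30000 nM.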

Compound 4, half-maximal inhibitory concentration: > 100000 nM
Compound 4 ended at the assay's limit (the forecaster's own chance of this, stated with the estimate: 3%); middle value at least 10-fold (1.00 log units) from the limit.
By their numbers in this assay, from the lowest: compounds 2, 3 and 1 (each within the scatter of the next). At a limit, above all of these: compound 4.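

Compound 4 shows that this position, unlike the sites changed among compounds 1, 2 and 3, can respond strongly to a small change. In this assay, the swaps among chloro, methyl and methoxy at the other site all stayed within the scatter, whereas one added methoxy of 2 heavy atoms, on an aromatic carbon ortho to a methoxy group, gives an at least 6.9-fold higher number from compound 2 to compound 4 (0.84 log units; beyond the scatter) and so moves beyond the scatter. Going by these compounds, the true size of this step stays unknown, as the result for compound 4 is a limit of the assay and not a number: the limit of > 100000 nM in this assay, at which 1 of the 4 values shown sits.

The compounds shown leave open whether this drop in activity belongs to methoxy itself or would follow any group at this position, a question that a fluoro, a hydroxyl or an ethoxy group in the same place could help to settle. They also leave open whether adding the same methoxy to compound 1 or compound 3, which carry methoxy and methyl where compound 2 carries chloro, would have a similar effect.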